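Dropping the (methylsulfonyl)methyl group from compound 2

The source may hold more compounds than are shown below. What is called first, only, known or untested is meant among the compounds shown, and "the series" means these compounds.

Three compounds in this series have numbers in a physicochemical assay for solubility, in phosphate buffer, measured as kinetic solubility, with a stated time of 1 h, at pH 7.4; a lower number here means a less soluble compound, a higher number a more soluble compound. Compound 1 `CS(=O)(=O)Cc1cc(C2=CCOCC2)nc(-c2cccc(O)c2)n1` gives 27 ug/mL, compound 2 `CCNC(=O)Nc1ccc(-c2nc(CS(C)(=O)=O)cc([C@]34CCOC[C@H]3C4)n2)cc1` gives 96 ug/mL, and compound 3 `CNCC(=O)Nc1ccc(-c2nc(CS(C)(=O)=O)cc([C@@]34CCOC[C@@H]3C4)n2)cc1` gives 167 ug/mL. Compound 2 and compound 3 lie within the usual scatter of repeated measurements, so these two cannot be ranked against each other. Compound 1 lies below compound 2 by more than that scatter.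

Compound 4 `CCNC(=O)Nc1ccc(-c2nccc([C@]34CCOC[C@H]3C4)n2)cc1` is compound 2 with one structural change: hydrogen in place of (methylsulfonyl)methyl on an aromatic carbon. Among the measured compounds shown here, all three measured compounds carry that group, and no measured pair differs in one place only. For the measured compounds named here, the data therefore contain no direct example of what this change does in this assay, and any forecast is a judgement rather than a reading from a matched pair.

The working expectation is a modest fall, slightly beyond the scatter, and not a collapse. The expected change is a 2.4-fold lower number from compound 2 to compound 4 (0.38 log units; beyond the scatter). For compound 4 the estimated value is 40 ug/mL, with an expected range from 12 ug/mL to 120 ug/mL.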

Compound 4, solubility: 125 ug/mL
Beside the measured number, compound 4's estimate is 3.1-fold (0.49 log units) below it, and the stated range ends below it.
By their numbers in this assay, from the lowest: compound 1; then compounds 2, 4 and 3 (each within the scatter of the next).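

In this assay, among the compounds shown here, the first pair to differ only at this position gives a 1.3-fold higher number from compound 2 to compound 4 (0.11 log units; within the scatter). With the (methylsulfonyl)methyl group on the aromatic carbon next to the ring nitrogen in compound 2 and hydrogen there in compound 4, the read-out does not separate the two compounds, so in this one pair the group can leave without a change that can be told from the scatter of repeated measurements. Nothing supplied here gives a measured property that would explain this result.

From the compounds shown here alone, this is a single example on a single background, and whether hydrogen in place of the same group would give a similar result alongside the other parts of compound 1 or compound 3 remains open, as neither has a partner that differs from it in this one place. Also open is how this assay would respond to an amine, a carboxylic acid or a longer chain on this same aromatic carbon, as the compounds shown carry only (methylsulfonyl)methyl or hydrogen there.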